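A Bromobenzyl Analogue Expected to Stay at the Limit

The compounds below may be only part of what the source reports. "The series", "measured", "known", "first", "only" and "open" are said of these compounds alone.

Compound 1, `CCC(C)Oc1ccc(C(O)C2OC(=O)c3c(OC)cc(OC)cc32)cc1`, gives > 40000 nM in an ADME assay on RAW264.7 cells (Mus musculus) for cytotoxicity, read by MTT assay, with a stated time of 24 h, in the presence of a further agent that is not named here (on this read-out higher numbers stand for weaker inhibition and lower numbers for stronger inhibition), which is a limit of the assay and not a number. Compound 2, `C=CCCOc1ccc(C(O)C2OC(=O)c3c(OC)cc(OC)cc32)cc1`, gives > 40000 nM in this assay, likewise a limit. Compound 3, `COc1cc(OC)c2c(c1)C(C(O)c1ccc(OCc3ccc(Cl)cc3)cc1)OC2=O`, gives > 40000 nM in this assay, again a limit.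

Compound 1 therefore stands only as a limit, as do both other measured compounds, all sitting at the limit of > 40000 nM in this assay, at which 3 of the 3 values shown sit. The steps a step that the two limits leave unreadable from compound 1 to compound 2 and a step that the two limits leave unreadable from compound 1 to compound 3 are accordingly unreadable in size, and so is a step that the two limits leave unreadable from compound 2 to compound 3. Compound 4, `COc1cc(OC)c2c(c1)C(C(O)c1ccc(OCc3ccc(Br)cc3)cc1)OC2=O`, differs from compound 1 by 4-bromobenzyl in place of sec-butyl on an oxygen on an aromatic ring. The nearest measured step, a step that the two limits leave unreadable from compound 1 to compound 3, offers no readable size, so no step beyond the scatter is expected in this assay. Compound 4 is therefore estimated at 80000 nM, ranging from 30000 nM to 300000 nM, most likely reported again as a limit, an expected step that the limit leaves unreadable from compound 1 to compound 4.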

Compound 4, half-maximal inhibitory concentration: > 40000 nM
Compound 4: a limit, no number; the forecaster's own chance of this, stated with the estimate: 85%; the middle value lies beyond the limit too.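

Among these compounds, compound 4, like compound 1, compound 2 and compound 3, stands only as a limit in this assay, so no step involving compound 4 can be read: the limit of > 40000 nM in this assay, at which 4 of the 4 values shown sit.

The compounds shown leave open whether any group on this oxygen would give a readable number in this assay.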